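The source may hold more compounds than are shown below. What is called first, only, known or untested is meant among the compounds shown, and "the series" means these compounds.

Measured in a functional assay on BXPC-3 cells (Homo sapiens) for antiproliferative activity, read by sulforhodamine B assay, with a stated time of 72 h; a lower number here means a stronger inhibitor, a higher number a weaker inhibitor:
- compound 1 `C=CCOC(=O)C1=C2C(=NC1=O)c1cccc3cccc2c13`: 4800 nM
- compound 2 `C=CCOC(=O)C1=C2C(=NC1=O)c1cccc3c(SCCC)ccc2c13`: 12900 nM
- compound 3 `CCCSC(=O)COC(=O)C1=C2C(=NC1=O)c1cccc3c(SCCC)ccc2c13`: 56300 nM

Compound 2 holds the second highest of the three numbers, with compound 1 lower and compound 3 higher. The next compound to be read is compound 4 `C=CCOC(=O)C1=C2C(=NC1=O)c1cccc3c(SCC=C)ccc2c13`, which differs from compound 2 as follows: vinyl in place of ethyl on a saturated chain carbon bound to a sulfur. In words, this is vinyl in place of ethyl on a saturated chain carbon bound to a sulfur, or propylsulfanyl to allylsulfanyl.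

Within the data shown here, two measured steps bear on this only indirectly. The arrival of propylsulfanyl gave a 2.7-fold higher number from compound 1 to compound 2 (0.43 log units; beyond the scatter), and (propylsulfanyl)carbonyl in place of vinyl gave a 4.4-fold higher number from compound 2 to compound 3 (0.64 log units; beyond the scatter). Both are modest, and neither alters the propyl chain itself, so the data do not test this change directly. With so small a change, no step beyond the scatter is expected in this assay. The expected change is a 1.2-fold lower number from compound 2 to compound 4 (0.07 log units; within the scatter). For compound 4 the estimated value is 11000 nM, with an expected range of 5000 nM to 25000 nM.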

Compound 4, half-maximal inhibitory concentration: 2500 nM
The estimate for compound 4 lay 4.4-fold (0.64 log units) above the measured number; the whole stated range lies above it.
By their numbers in this assay, from the lowest: compounds 4 and 1 (each within the scatter of the next); then compound 2; then compound 3.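

In this assay the change on a saturated chain carbon bound to a sulfur proves far from neutral, giving a 5.2-fold lower number from compound 2 to compound 4 (0.71 log units; beyond the scatter) even though propyl to allyl keeps the heavy-atom count and adds only one double bond outside aromatic rings. The cost seen on adding propylsulfanyl therefore does not extend to allylsulfanyl, which gives a 1.9-fold lower number from compound 1 to compound 4 (0.28 log units; within the scatter) and leaves compound 4 and compound 1 within the scatter of each other. Nothing available explains this difference between two closely related chains.

From the compounds shown here alone, whether the gain needs the double bond or would also appear with a propargyl group or a longer chain such as butenyl remains open. Also open, going by these compounds, is how an amine or a carboxylic acid would read on that same sulfur-bound chain.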